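This account rests on a few compounds, and the source may have more. Where it says the series, first, only, none or still open, it means among the compounds named here.

Compound 1 `COc1cc2nc(N3CCN(C(=O)c4cccc5ccccc45)CC3)nc(N)c2cc1OC`: in a functional assay on PC-3 cells (Homo sapiens) for inhibition (on this read-out higher numbers stand for weaker inhibition and lower numbers for stronger inhibition), compound 1 gives 59000 nM.
Compound 2 `COc1cc2nc(N3CCN(S(=O)(=O)c4ccc(Br)cc4)CC3)nc(N)c2cc1OC`: in this assay compound 2 gives 20000 nM.

Of these two numbers, compound 2 shows the lower one, and the number of compound 1 lies beyond the scatter above it. Compound 3 `COc1cc2nc(N3CCN(S(=O)(=O)c4ccc([N+](=O)[O-])cc4)CC3)nc(N)c2cc1OC` differs from compound 2 by nitro in place of bromo on an aromatic carbon. Among the compounds with values here, no measured pair in this set carries that change, so nothing here tells its size or direction; the step from compound 2 to compound 3 in this assay is therefore expected to stay within the scatter, with no change at the digits printed from compound 2 to compound 3 (within the scatter) as the estimated step. Compound 3 is thus expected to give about 20000 nM, between 6000 nM and 60000 nM.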

Compound 3, half-maximal inhibitory concentration: 36000 nM
The estimate for compound 3 lay 1.8-fold (0.26 log units) below the measured number; the range from low to high includes it.
By their numbers in this assay, from the lowest: compounds 2, 3 and 1 (each within the scatter of the next, the first and the last beyond it).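

In this assay, the first step measured in this set, 4-bromophenyl to 4-nitrophenyl, gives a 1.8-fold higher number from compound 2 to compound 3 (0.26 log units; within the scatter). At this position, para to a large group, one heavy atom can thus give way to three, with two hydrogen-bond acceptors entering, and the read-out stays within the scatter for this pair. Nothing available accounts for this result.

On these data alone, whether an amine or a carboxylic acid at this position would also stay within the scatter remains open. So does the effect of the sulfonyl link alone, as compound 1 differs from compound 2 in more than one place.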